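Removing the 3-fluorophenyl from a coumarin propargylamine

The compounds below may be only part of what the source reports. "The series", "measured", "known", "first", "only" and "open" are said of these compounds alone.

Of the compounds shown here, three sharing one core have been tested in an ADME assay on isolated protein for inhibition of Amine oxidase [flavin-containing] A (Homo sapiens), read by fluorescence and Amplex Red, with stated times of 15 min and 20 min; on this read-out higher numbers stand for weaker inhibition and lower numbers for stronger inhibition. Compound 2 `C#CCN(CCCOc1ccc2ccc(=O)oc2c1)Cc1cccc(F)c1` gives 29300 nM, compound 1 `C#CCN(CCCCOc1ccc2ccc(=O)oc2c1)Cc1ccc(C(C)C)cc1` gives 35400 nM, and compound 3 `C#CCN(CCCCOc1ccc2ccc(=O)oc2c1)Cc1cccc(OC)c1` gives 78600 nM. Compound 2 thus holds the lowest of the three numbers, though its gap to compound 1 lies within the scatter, so the two cannot be ranked; only compound 3 stands clearly apart, and the change a 2.2-fold higher number from compound 1 to compound 3 (0.35 log units; beyond the scatter) shows how much a swap of the aromatic group on this saturated chain carbon can move the read-out.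

Compound 4 `C#CCN(C)CCCOc1ccc2ccc(=O)oc2c1` is the next compound. The change from compound 2 is hydrogen in place of 3-fluorophenyl on a saturated chain carbon bound to an amine nitrogen. Among the measured compounds shown here, no measured step removes the aromatic group altogether; the nearest guide is the step from compound 1 to compound 3, which only exchanges one aromatic group for another and is modest in size. With the whole 3-fluorophenyl gone, a shift in this assay larger than that, toward a higher number, seems more likely than no shift, but the uncertainty is wide.

Compound 4 is therefore expected to give about 65000 nM, with a plausible range from 20000 nM to 210000 nM. That estimate means a step of a 2.2-fold higher number from compound 2 to compound 4 (0.35 log units; beyond the scatter).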

Compound 4, half-maximal inhibitory concentration: 36900 nM
Beside the measured number, compound 4's estimate is 1.8-fold (0.25 log units) above it; measured number inside the range.
By their numbers in this assay, from the lowest: compounds 2, 1 and 4 (each within the scatter of the next); then compound 3.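

Cutting away the whole 3-fluorophenyl, with its 7 heavy atoms and its aromatic ring, gives a 1.3-fold higher number from compound 2 to compound 4 (0.10 log units; within the scatter) in this assay, so compound 2 and compound 4 cannot be told apart on this read-out. Among the compounds shown here, the earlier compounds showed only one aromatic group exchanged for another, in a 2.2-fold higher number from compound 1 to compound 3 (0.35 log units; beyond the scatter), and that swap left the two numbers clearly apart; this new pair shows that, with the chain of compound 2, inhibition at this place on a saturated chain carbon bound to an amine nitrogen does not depend on having the 3-fluorophenyl there at all. No measurement offered here explains why the aromatic group can go without a visible effect.

Still open, from the compounds shown here alone, is whether the same holds on the longer chain of compound 1 and compound 3, where a methyl on the amine nitrogen in place of the substituted benzyl would make the matching pair. Also open, going by these compounds, is what a group of a different kind at this place, such as a cyclohexyl ring or a pyridine ring, would do to the number.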